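Benzyl in place of methylcarbamoyl on the ring nitrogen

A few compounds are considered here, and "the series" means these few. Any claim that something is new, unique, unknown or untested is made for them only; others in the source may bear on it.

Going by the values given here, the three measured members share one core and differ in what sits on the ring nitrogen and in the side chain. In a functional assay on the whole organism with Canis familiaris (Canis lupus familiaris) as the target, at a dose of 5 mg/kg by the intravenous route (on this read-out lower numbers stand for a weaker effect and higher numbers for a stronger effect at the one dose given), compound 1 `Cc1nc2c(COc3ccccc3)cccn2c1N` gives 34%, compound 2 `Cc1nc2c(CCc3ccccc3)nccn2c1N` gives 18%, and compound 3 `CNC(=O)Nc1c(C)nc2c(OCc3ccccc3)cccn12` gives 27%. Compound 3 holds the second highest of the three numbers; its nearest neighbour is compound 1, whose number lies within the scatter, and the furthest is compound 2, whose number also lies within the scatter. Among the compounds with values here, on these three numbers no compound separates from the others beyond the scatter, so no order among them is claimed.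

Compound 4 `Cc1nc2c(OCc3ccccc3)cccn2c1NCc1ccccc1` has not been measured in this assay. Its difference from compound 3 is benzyl in place of methylcarbamoyl on a nitrogen on an aromatic ring. Within the data shown here, no step between two measured compounds isolates this change, so there is no measured precedent for its size. With compound 1, which carries no substituent on that nitrogen, giving 34% and compound 3 giving 27%, the measured range is narrow, and the expectation for compound 4 is a step no larger than the scatter in either direction. The expected step is a number 3 percentage points higher from compound 3 to compound 4 (within the scatter). The estimate for compound 4 in this assay is 30%, with a range from 15% to 45%.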

Compound 4, a percentage reported as inhibition, in the whole organism at one dose (the size of the read-out at that dose, not a potency): 0%
Compound 4: the middle estimate sits 30 percentage points above what was measured, and the stated range ends above it.
By their numbers in this assay, from the lowest: compound 4; then compounds 2, 3 and 1 (each within the scatter of the next, the first and the last beyond it).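

In this assay, going by these compounds alone, benzyl in place of methylcarbamoyl on a nitrogen on an aromatic ring gives a number 27 percentage points lower from compound 3 to compound 4 (beyond the scatter), the first step that isolates a single change at this position and the first to lie beyond the scatter. This nitrogen is therefore not indifferent to what it carries: with benzyl, compound 4 gives 0%, so no effect is recorded at the one dose given, and a dose that shows nothing cannot say how much weaker compound 4 is. No measurement at hand accounts for the size of this step.

The change removes a carbonyl and the hydrogen-bond donor and acceptor of methylcarbamoyl while adding a six-membered aromatic ring of carbon only, and the compounds shown do not separate the loss of the one from the arrival of the other. Acetyl on the same nitrogen would keep a carbonyl without the terminal methylamino part, and a small alkyl such as ethyl would carry neither a carbonyl nor a ring, so these two groups would start to divide the step.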